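One group exchanged on compound 2

The source may report more compounds than this note shows. Statements on the series, on what has been measured and on what is new or still open speak of the compounds shown alone.

compound 1 `COC(=O)c1cccc(NC(=O)Nc2cc(C)nc3ccccc23)c1` gives 746 10^-6 cm/s
compound 2 `Cc1cc(NC(=O)Nc2ncccc2C)c2ccccc2n1` gives 369 10^-6 cm/s

In an ADME assay for permeability, using PAMPA, at pH 7.4 (a higher number here means that the compound crosses the layer faster, a lower number that the compound crosses the layer more slowly), compound 2 gives 369 10^-6 cm/s as the lower of the two numbers, a gap beyond the scatter from compound 1. Compound 3 `Cc1cc(NC(=O)Nc2cccc(Cl)c2)c2ccccc2n1` carries 3-chlorophenyl in place of 3-methylpyridin-2-yl on an amide-type nitrogen and is still unmeasured. Among the compounds with values here, no measured pair shows this exchange, so the only guide is the higher number of compound 1 at 746 10^-6 cm/s on the shared core. A small rise within the scatter is expected, with the estimated step of a 1.6-fold higher number from compound 2 to compound 3 (0.21 log units; within the scatter) for this exchange. For compound 3 the estimated value is 600 10^-6 cm/s with an expected range from 300 10^-6 cm/s to 1200 10^-6 cm/s in the coming measurement.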

Compound 3, apparent permeability: 566 10^-6 cm/s
Beside the measured number, compound 3's estimate is 1.1-fold (0.03 log units) above it; measured number inside the range.
By their numbers in this assay, from the lowest: compounds 2, 3 and 1 (each within the scatter of the next, the first and the last beyond it).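

In this assay, replacing 3-methylpyridin-2-yl with 3-chlorophenyl on an amide-type nitrogen gives a 1.5-fold higher number from compound 2 to compound 3 (0.19 log units; within the scatter), so this exchange of a ring nitrogen for a chlorine-bearing carbon ring cannot be told apart from no change. Chloro in place of methoxycarbonyl on an aromatic carbon gives a 1.3-fold lower number from compound 1 to compound 3 (0.12 log units; within the scatter), which likewise cannot be told apart from no change. No measurement at hand offers an explanation for either step. As far as these compounds go, it remains open whether an amine or a carboxylic acid on that aromatic carbon would shift the number beyond the scatter.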